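Removing the Aromatic Methyl: What to Expect for Compound 4

The source may hold more compounds than are shown below. What is called first, only, known or untested is meant among the compounds shown, and "the series" means these compounds.

Measured so far in an in vitro assay on cells for inhibition of Amine oxidase [flavin-containing] B (Homo sapiens), read by Amplex Red, with a stated time of 15 min, tested at 100 uM; a lower number here means less inhibition, a higher number more inhibition at the concentration tested (going by the name of the read-out):
- compound 1 `CNC(=S)N1CC(C)C(c2ccc(F)cc2)=N1`: 40%
- compound 2 `CNC(=S)N1CC(C)C(c2ccc(C)cc2)=N1`: 40%
- compound 3 `Cc1ccc(C2=NN(C(N)=S)CC2C)cc1`: 40%

Compound 2 stands level with the other two at the digits shown. Going from compound 1 to compound 2, where methyl replaces fluoro on the aromatic carbon, the read-out moved by no change at the digits printed from compound 1 to compound 2 (within the scatter). Going from compound 2 to compound 3, where hydrogen replaces methyl on the amide-type nitrogen, it moved by no change at the digits printed from compound 2 to compound 3 (within the scatter). Neither change left the scatter.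

Compound 4 `CNC(=S)N1CC(C)C(c2ccccc2)=N1` differs from compound 2 by hydrogen in place of methyl on an aromatic carbon. The step from compound 1 to compound 2 bears most directly on this, since it altered the same aromatic carbon and produced no change beyond the scatter; the step from compound 2 to compound 3 shows the same flatness elsewhere in the shared core. The expected step from compound 2 to compound 4 is therefore no change at the digits printed from compound 2 to compound 4 (within the scatter), none beyond the scatter. Compound 4 is estimated at 40%, ranging from 28% to 52%.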

Compound 4, a percentage reported as inhibition, at one concentration (the size of the read-out at that concentration, not a potency): 40%
Estimate against measurement, compound 4: no gap at the digits printed; the range from low to high includes it.
By their numbers in this assay, from the lowest: compounds 1, 2, 3 and 4 (each within the scatter of the next).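

In this assay, hydrogen in place of methyl gave no change at the digits printed from compound 2 to compound 4 (within the scatter) and hydrogen in place of fluoro gave no change at the digits printed from compound 1 to compound 4 (within the scatter) on the same aromatic carbon. The earlier compounds shown here only exchanged one substituent for another at this carbon, para to a large group, whereas these steps show that the read-out at the single concentration tested does not depend on having either methyl or fluoro there. Nothing available here offers an explanation for this flatness.

From the compounds shown here alone, whether an amine, a carboxylic acid or a longer chain on this aromatic carbon would move the read-out remains open. Because the read-out is a percentage at one concentration and not a potency, the compounds shown also leave open whether any differences would appear at other concentrations.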